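The source may hold more compounds than are shown below. What is called first, only, known or untested is meant among the compounds shown, and "the series" means these compounds.

Measured so far in an ADME assay on LLC-MK2 cells (Macaca mulatta) for cytotoxicity, read by spectrophotometry and crystal violet staining, with a stated time of 4 days; on this read-out higher numbers stand for lower toxicity in this test and lower numbers for higher toxicity in this test:
compound 1 `CC(C)n1ncc2c(C(=O)Nc3ccc(F)cc3)cc(-c3ccsc3)nc21` — > 200000 nM
compound 2 `CC(C)n1ncc2c(C(=O)Nc3cccnc3)cc(-c3ccsc3)nc21` — 37000 nM

The value shown for compound 1 in this assay is a limit of the assay, not a number. The series therefore contains (the limit of > 200000 nM in this assay, at which 1 of the 2 values shown sits). Compound 2 stands as the only number shown in this assay, with no second number to rank it against.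

Within the data shown here, the single measured step is an at least 5.4-fold lower number from compound 1 to compound 2 (0.73 log units; beyond the scatter), the replacement of 4-fluorophenyl by pyridin-3-yl on the amide-type nitrogen. Compound 3 `CC(C)n1ncc2c(C(=O)Nc3ncccn3)cc(-c3ccsc3)nc21` differs from compound 2 at the same amide-type nitrogen: pyrimidin-2-yl in place of pyridin-3-yl on an amide-type nitrogen. Among the measured compounds shown here, no measured step covers this exchange of one six-membered aromatic ring for another at that position, so the step from compound 1 to compound 2 bears on it only by place, not by direction or size. Nothing beyond the scatter is expected in this assay.

Compound 3 is expected near 50000 nM, with a range from 15000 nM to 200000 nM. This estimate means a step of a 1.4-fold higher number from compound 2 to compound 3 (0.13 log units; within the scatter), within the scatter.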

Compound 3, half-maximal cytotoxic concentration: 50000 nM
Estimate against measurement, compound 3: no gap at the digits printed, and the stated range covers the measured number.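

In this assay, pyrimidin-2-yl in place of pyridin-3-yl on the amide-type nitrogen gives a 1.4-fold higher number from compound 2 to compound 3 (0.13 log units; within the scatter), so at this position a six-membered aromatic ring with 2 hetero atoms cannot be told apart from one with 1 hetero atom. Pyrimidin-2-yl in place of 4-fluorophenyl gives an at least 4.0-fold lower number from compound 1 to compound 3 (0.60 log units; beyond the scatter), which makes it the second nitrogen-bearing ring to read apart from 4-fluorophenyl at this position. The value of compound 1 is a limit of the assay, not a number, so the full size of this step stays open: the limit of > 200000 nM in this assay, at which 1 of the 3 values shown sits.

As far as these compounds go, it remains open whether the difference from compound 1 goes with the ring nitrogen or with the loss of fluorine, which an unsubstituted phenyl on the amide-type nitrogen would separate. Also open, from the compounds shown here alone, is how a non-aromatic group there, such as cyclohexyl or a longer alkyl chain, would read in this assay.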